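The source may hold more compounds than are shown below. What is called first, only, known or untested is meant among the compounds shown, and "the series" means these compounds.

Compound 1 `COC(=O)[C@@]1(C)CCC=C2[C@@H]1CC[C@@H](C)[C@]2(C)Cc1c(C)[nH]c2ccc(F)cc12` and compound 2 `COC(=O)[C@@]1(C)CCC=C2[C@@H]1CC[C@@H](C)[C@]2(C)Cc1c(C)[nH]c2ccc(OC)cc12` share one core; compound 3 `COC(=O)[C@@]1(C)CC[C@@H]2C3=C1CC[C@@H](C)[C@]3(C)C[C@@H]1c3cc(F)ccc3N[C@H]21` and compound 4 `COC(=O)[C@@]1(C)CC[C@@H]2C3=C1CC[C@@H](C)[C@]3(C)C[C@@H]1c3cc(OC)ccc3N[C@H]21` share another, and the difference between the two cores is not broken down here. In a functional assay on SW1573 cells (Homo sapiens) for inhibition, read by sulforhodamine B assay, with a stated time of 48 h (on this read-out lower numbers stand for stronger inhibition of growth and higher numbers for weaker inhibition of growth), compound 1 gives 12000 nM and compound 2 gives 15000 nM; the change between them is methoxy in place of fluoro on an aromatic carbon, and it made a 1.3-fold higher number from compound 1 to compound 2 (0.10 log units; within the scatter). Compound 3 gives 27000 nM in this assay. Compound 4 carries the same kind of change, (methoxy in place of fluoro on an aromatic carbon), though here the aromatic ring is part of a fused or bridged system of five rings rather than two. Because a 1.3-fold higher number from compound 1 to compound 2 (0.10 log units; within the scatter) stayed within the scatter, the step of a 1.3-fold higher number from compound 3 to compound 4 (0.11 log units; within the scatter) is expected to be small as well. Compound 4 is therefore estimated to give about 35000 nM in this assay, likely between 15000 nM and 80000 nM.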

Compound 4, concentration for 50% growth inhibition: 25000 nM
Beside the measured number, compound 4's estimate is 1.4-fold (0.15 log units) above it, and the stated range covers the measured number.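

In this assay, the same swap of fluoro for methoxy on the other core gives a 1.1-fold lower number from compound 3 to compound 4 (0.03 log units; within the scatter) and so leaves the number about where it was. Going by these compounds alone, this rests on only two pairs of compounds, and it does not show why the swap does so little or whether a change with a larger effect would carry over in the same way. Within these two pairs, the small effect of the swap carries from one core to the other: the same change on two cores in this assay, a 1.3-fold higher number (0.10 log units; within the scatter) from compound 1 to compound 2 and a 1.1-fold lower number (0.03 log units; within the scatter) from compound 3 to compound 4, 1.4-fold (0.13 log units) apart, within the scatter of two such steps.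

The compounds shown carry only fluoro or methoxy at this place on the aromatic ring. On these data alone, whether an amine, a carboxylic acid or a longer chain there would move the number on either core stays open.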